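The source may report more compounds than this note shows. Statements on the series, on what has been measured and on what is new or still open speak of the compounds shown alone.

Compound 1 `CCn1c(C(=O)NCCN(C)C)ccc1C(CC)(CC)c1ccc(OCCC(O)(CC)CC)c(C)c1`: 870 nM
Compound 2 `C=CCN(C)C(=O)c1ccc(C(CC)(CC)c2ccc(OCCC(O)(CC)CC)c(C)c2)n1CC`: 12800 nM
Compound 3 `C#CCCOC(=O)c1ccc(C(CC)(CC)c2ccc(OCCC(O)(CC)CC)c(C)c2)n1CC`: > 50000 nM

In a functional assay on PC-3 cells (Homo sapiens) for antiproliferative activity, read by MTT assay, with a stated time of 48 h (a lower number here means a stronger inhibitor, a higher number a weaker inhibitor), compound 3 stands at > 50000 nM, which is a limit and not a measured number. Compound 4 `CCC(C)C(NC(=O)c1ccc(C(CC)(CC)c2ccc(OCCC(O)(CC)CC)c(C)c2)n1CC)C(=O)OC` changes the group on a carbonyl carbon: a group of 10 heavy atoms (7 carbon, 1 nitrogen, 2 oxygen; no ring) in place of a group of 5 heavy atoms (4 carbon, 1 oxygen; no ring), on a carbonyl carbon.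

Going by the values given here, two measured steps bear on this, an at least 57-fold higher number from compound 1 to compound 3 (1.75 log units; beyond the scatter) and an at least 3.9-fold higher number from compound 2 to compound 3 (0.59 log units; beyond the scatter). Both put the (but-3-yn-1-yl)oxy group in place of a nitrogen-linked group, and both are beyond the scatter. Compound 4 restores nitrogen at that carbonyl carbon but lacks the (2-(dimethylamino)ethyl)amino group, so a result near compound 2 at 12800 nM seems likelier than one near compound 1 at 870 nM.

A move to a lower number is therefore expected, estimated as an at least 3.3-fold lower number from compound 3 to compound 4 (0.52 log units; beyond the scatter). For compound 4 the expected value is 15000 nM, with an estimated range of 4000 nM to 50000 nM.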

Compound 4, half-maximal inhibitory concentration: > 50000 nM
Compound 4: no number, only a limit (the forecaster's own chance of this, stated with the estimate: 25%); middle value at least 3.3-fold (0.52 log units) away from the limit.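

In this assay, a nitrogen on the carbonyl carbon does not by itself keep activity: the larger nitrogen-linked group gives an at least 3.9-fold higher number from compound 2 to compound 4 (0.59 log units; beyond the scatter), and an at least 57-fold higher number from compound 1 to compound 4 (1.75 log units; beyond the scatter). The step between compound 3 and compound 4 cannot be read, because both sit at one limit: the limit of > 50000 nM in this assay, at which 2 of the 4 values shown sit.

Still open, going by these compounds, is whether a carboxylic acid on the new group, or a longer amine chain such as (3-(dimethylamino)propyl)amino, would move the number back toward that of compound 1 at 870 nM.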